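Swapping a five-membered for a six-membered ring

The source may hold more compounds than are shown below. What is called first, only, known or untested is meant among the compounds shown, and "the series" means these compounds.

This account concerns a small set of thienopyrimidine-type compounds examined in a functional assay on CHO-K1 cells for antagonist activity at adenosine receptor A1 (Homo sapiens), read by a beta-galactosidase reporter and cAMP accumulation, with stated times of 15 min and 6 h; a lower number here means a stronger inhibitor, a higher number a weaker inhibitor. Compound 1 `Nc1nc(-c2ncco2)nc2sc(Cc3ccccc3)cc12` gives 310 nM in this assay, the lowest of the two numbers recorded. Compound 2 `CC(c1ccccc1)c1cc2c(N)nc(-c3cccc(C#N)c3)nc2s1`, which carries a different side chain and a nitrile-bearing phenyl ring in place of the five-membered heterocycle, gives 1770 nM in this assay, a gap from compound 1 that lies beyond the usual scatter.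

Compound 3 `Nc1nc(-c2ncccn2)nc2sc(Cc3ccccc3)cc12` has not yet been measured. It differs from compound 1 in one place: pyrimidin-2-yl in place of 1,3-oxazol-2-yl on an aromatic carbon. Both groups are aromatic rings with two hetero atoms and two hydrogen-bond acceptors, so the change is modest in kind. For the measured compounds named here, no measured pair shows the effect of this exchange. The step from compound 1 to compound 3 is therefore expected to be small, with a 1.8-fold higher number from compound 1 to compound 3 (0.25 log units; within the scatter) pointing toward a somewhat higher number. Compound 3 is estimated at 550 nM in this assay, within a range from 150 nM to 2000 nM.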

Compound 3, inhibition constant: 618 nM
Compound 3: the middle estimate sits 1.1-fold (0.05 log units) below what was measured; the measured number falls inside the stated range.
By their numbers in this assay, from the lowest: compounds 1 and 3 (each within the scatter of the next); then compound 2.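

In this assay, for the compounds shown here, placing pyrimidin-2-yl instead of 1,3-oxazol-2-yl on the aromatic carbon between two ring nitrogen atoms gives the first one-place comparison in this set (a 2.0-fold higher number from compound 1 to compound 3 (0.30 log units; within the scatter)). At this position, with the rest of the core of compound 1 held fixed, a six-membered aromatic ring therefore reads the same as a five-membered one within the scatter. Nothing available here speaks to the reason for this result.

On these data alone, it remains open how this position would respond to a plain phenyl ring, a morpholine or a simple amine in place of these two rings. As far as these compounds go, it is also open whether the same exchange would read alike when paired with the side chain of compound 2.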